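Trifluoromethyl-for-dichloro swap on the thioether benzyl

This account rests on a few compounds, and the source may have more. Where it says the series, first, only, none or still open, it means among the compounds named here.

Measured compounds:
compound 1 `Cn1nc(-c2nnc(SCc3cccc(Cl)c3Cl)o2)cc1-c1ccc(C(F)(F)F)cc1`: 32200 nM
compound 2 `Cn1nc(-c2nnc(SCc3ccc(C(F)(F)F)cc3)o2)cc1-c1ccc(C(F)(F)F)cc1`: 15500 nM
compound 3 `Cn1nc(-c2ccc(C(F)(F)F)cc2)cc1-c1nnc(SCc2cccc(Cl)c2Cl)o1`: 60200 nM

In a functional assay on MCF7 cells (Homo sapiens) for cytotoxicity, read by MTT assay, with a stated time of 24 h (on this read-out lower numbers stand for stronger inhibition and higher numbers for weaker inhibition), compound 3 gives the highest number of the three, while compound 1 and compound 3 lie within the scatter of each other. Compound 1 and compound 3 have the same atoms joined differently; the difference between the two cores is not broken down here. Among the compounds with values here, the one counted change is 4-(trifluoromethyl)phenyl in place of 2,3-dichlorophenyl on a saturated chain carbon bound to a sulfur, which gave a 2.1-fold lower number from compound 1 to compound 2 (0.32 log units; beyond the scatter). The same change, (4-(trifluoromethyl)phenyl in place of 2,3-dichlorophenyl on a saturated chain carbon bound to a sulfur), leads from compound 3 to the unmeasured compound 4 `Cn1nc(-c2ccc(C(F)(F)F)cc2)cc1-c1nnc(SCc2ccc(C(F)(F)F)cc2)o1`. Because the step of a 2.1-fold lower number from compound 1 to compound 2 (0.32 log units; beyond the scatter) was modest but beyond the scatter, a similar step is expected here: a 2.1-fold lower number from compound 3 to compound 4 (0.32 log units; beyond the scatter). Compound 4 is therefore estimated at 29000 nM in this assay, with a range from 12000 nM to 70000 nM; this rests on one pair only.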

Compound 4, half-maximal inhibitory concentration: 27100 nM
Beside the measured number, compound 4's estimate is 1.1-fold (0.03 log units) above it; the range from low to high includes it.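

In this assay, 4-(trifluoromethyl)phenyl in place of 2,3-dichlorophenyl on a saturated chain carbon bound to a sulfur gave a 2.2-fold lower number from compound 3 to compound 4 (0.35 log units; beyond the scatter). The change carried from one core to the other with its size kept: the same change on two cores in this assay, a 2.1-fold lower number (0.32 log units; beyond the scatter) from compound 1 to compound 2 and a 2.2-fold lower number (0.35 log units; beyond the scatter) from compound 3 to compound 4, 1.1-fold (0.03 log units) apart, within the scatter of two such steps. This rests on two cores and one pair of groups, so it does not show that the step would hold on a further core, and it says nothing about why the numbers move.

Open, on these data alone, is whether a carboxylic acid, an amine or a longer chain in place of the 4-(trifluoromethyl)benzyl would shift the number further on either core. Also open, as far as these compounds go, is whether the step holds in another cell line.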